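Series notes: hexyloxy in place of pyrrolidin-1-yl

This account rests on a few compounds, and the source may have more. Where it says the series, first, only, none or still open, it means among the compounds named here.

Compound 1 `CNc1nc(N)nc2c1ncn2/C=C1/CC1(CO)CO` sets the shared core of the series. In an ADME assay on MOLT-3 cells (Homo sapiens) for cytotoxicity, with a stated time of 7 days (a lower number here means that less compound is tolerated, a higher number that more compound is tolerated), compound 1 gives only a limit, > 20000 nM. Compound 2 `CC(C)Nc1nc(N)nc2c1ncn2/C=C1/CC1(CO)CO` has no result in this assay, recorded as "not determined" (no result reported). Compound 3 `Nc1nc(N2CCCC2)c2ncn(/C=C3/CC3(CO)CO)c2n1` likewise has no result in this assay, recorded as "not determined" (no result reported). Compound 3 therefore stands without a number of its own; of the three entries shown, one is a limit of > 20000 nM in this assay, at which 1 of the 3 values shown sits, and two are blank. Going by the values given here, no step between measured compounds exists, so no measured change in tolerated concentration can be pointed to.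

Compound 4 `CCCCCCOc1nc(N)nc2c1ncn2/C=C1/CC1(CO)CO` differs from compound 3 in one place: hexyloxy in place of pyrrolidin-1-yl on an aromatic carbon. Among the compounds with values here, with no measured step available, no direction beyond the scatter can be read from the data for this assay; the expectation rests on compound 1 alone, which sits at the limit (the limit of > 20000 nM in this assay, at which 1 of the 3 values shown sits). Compound 4 is expected to give about 30000 nM in this assay, with an estimated range from 8000 nM to 100000 nM, and a real chance that only a limit is reported again.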

Compound 4, half-maximal cytotoxic concentration: > 20000 nM
Compound 4 gave a limit, no number; the forecaster's own chance of this, stated with the estimate: 60%; the middle value is on the limit's open side.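

Compound 1 and compound 4 each give only a limit, so no new step can be read between them: the limit of > 20000 nM in this assay, at which 2 of the 4 values shown sit.

The compounds shown leave open where the tolerated concentration of compound 1 or compound 4 lies, and whether hexyloxy in place of methylamino on an aromatic carbon changes it at all in this assay.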